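A Thiazole in Place of Phenyl on the Amide

The source may hold more compounds than are shown below. What is called first, only, known or untested is meant among the compounds shown, and "the series" means these compounds.

Measured compounds:
compound 1 `O=C(Nc1ccc(Cl)c(-c2nnc3c(Cl)cccn23)c1)c1ccc(C(F)(F)F)cc1F` — > 100000 nM
compound 2 `O=C(Nc1ccc(Cl)c(-c2nnc3c(Cl)cccn23)c1)c1ccccc1` — 73500 nM

Of the compounds shown here, two sharing the same core have been measured for antiproliferative activity in a functional assay on U-251 cells (Homo sapiens) for antiproliferative activity, read by MTT assay, with a stated time of 72 h; on this read-out lower numbers stand for stronger inhibition and higher numbers for weaker inhibition. Compound 1 `O=C(Nc1ccc(Cl)c(-c2nnc3c(Cl)cccn23)c1)c1ccc(C(F)(F)F)cc1F` reaches only the limit of this assay, > 100000 nM. Among the measured compounds shown here, compound 2 `O=C(Nc1ccc(Cl)c(-c2nnc3c(Cl)cccn23)c1)c1ccccc1` gives 73500 nM in this assay, which is the only actual number recorded. For the measured compounds named here, the one other value, that of compound 1, is a limit (the limit of > 100000 nM in this assay, at which 1 of the 2 values shown sits). Compound 2 thus stands on its own: there is no second number to rank it against.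

Compound 3 `Cc1nc(C(=O)Nc2ccc(Cl)c(-c3nnc4c(Cl)cccn34)c2)cs1` has not yet been measured. It differs from compound 2 in one place:

2-methyl-1,3-thiazol-4-yl in place of phenyl on a carbonyl carbon

Without a measured step between compounds of this kind, the size and direction of the change in this assay are open. A modest step is expected, within or close to the usual scatter, and no large gain is anticipated. The step expected from compound 2 to compound 3 is a 1.2-fold lower number from compound 2 to compound 3 (0.09 log units; within the scatter). Compound 3 is estimated to give 60000 nM in this assay, with a plausible range from 20000 nM to 150000 nM.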

Compound 3, half-maximal inhibitory concentration: 74300 nM
The estimate for compound 3 lay 1.2-fold (0.09 log units) below the measured number, within the range that was stated.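

Among the compounds shown here, this is the first measured step at this place on the carbonyl carbon, and in this assay it comes out as a 1.0-fold higher number from compound 2 to compound 3 (0.00 log units; within the scatter). The change swaps phenyl, a six-membered aromatic ring of carbon only, for 2-methyl-1,3-thiazol-4-yl, a five-membered aromatic ring that brings in a nitrogen and a sulfur and has 2 hydrogen-bond acceptors where phenyl has 0, while the count of 6 heavy atoms stays the same. Even so, the read-out gives no sign of a change, so this exchange of rings neither gains nor loses anything that this measurement can detect.

For the compounds shown here, compound 1 gives only a limit of the assay, so no step to it can be read: the limit of > 100000 nM in this assay, at which 1 of the 3 values shown sits. Still open, on these data alone, is whether a group of another kind on this carbonyl carbon, such as an amine, a carboxylic acid or a longer alkyl chain, would move the number at all, since the two groups compared here are both single aromatic rings of the same heavy-atom count.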